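The compounds below may be only part of what the source reports. "The series", "measured", "known", "first", "only" and "open" are said of these compounds alone.

Measured so far:
Compound 1, `OCCCC(F)CF`, in a physicochemical assay for lipophilicity, read by NMR; a lower number here means a more polar compound, a higher number a more lipophilic compound: 0.11
Compound 2, `OCCC(F)CF`: -0.12
Compound 3, `OCCCC(F)(F)CF`: 0.58

Compound 1 stands second highest of these three numbers. Its nearest neighbour is compound 2, with a number 0.23 log units lower from compound 1 to compound 2 (within the scatter); its furthest is compound 3, with a number 0.47 log units higher from compound 1 to compound 3 (beyond the scatter). The step to compound 2 is a change at the hydroxy end of the chain, the step to compound 3 adds a fluoro on a chain carbon already bound to a fluorine.

Compound 4, `CC(F)CCCO`, differs from compound 1 as follows: hydrogen in place of fluoro on a saturated chain carbon, two bonds along the chain from a fluorine atom. Within the data shown here, of the measured steps, only the one from compound 1 to compound 3 concerns a change in the number of fluorines, and it was modest and beyond the scatter. It does not point cleanly in a direction for compound 4, since there a fluoro entered a carbon bound to a fluorine, whereas here a fluoro leaves a fluoromethyl to give a methyl. A step of similar size is therefore expected, and compound 4 is estimated to read higher, with a number 0.34 log units higher from compound 1 to compound 4 (beyond the scatter), though a result within the scatter of compound 1 would not be surprising. The estimate for compound 4 in this assay is 0.45, within a range from 0.05 to 0.85.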

Compound 4, partition coefficient: 0.52
Compound 4: middle estimate off by 0.07 log units, on the low side; the range from low to high includes it.
By their numbers in this assay, from the lowest: compounds 2 and 1 (each within the scatter of the next); then compounds 4 and 3 (each within the scatter of the next).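

In this assay, the change of fluoromethyl to methyl removes a fluorine, yet the number goes up, with a number 0.41 log units higher from compound 1 to compound 4 (beyond the scatter) as a modest step. The only earlier change in the count of fluorines, a number 0.47 log units higher from compound 1 to compound 3 (beyond the scatter), added a fluoro on a different carbon, so a fluorine entering at one place and a fluorine leaving at another now both move the number upward from the same parent, and among these compounds the count of fluorines alone does not set the direction. Nothing available here bears on why this step takes the direction it does.

The compounds shown leave open whether the change of fluoromethyl to methyl would give a step of the same direction and similar size on a longer chain, or in a compound carrying an amine or a carboxylic acid in place of the hydroxy group. They also leave open whether replacing the fluoromethyl with a trifluoromethyl or a difluoromethyl group would continue this upward move or reverse it.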